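Changing the Aryl Group on Compound 2

A few compounds are considered here, and "the series" means these few. Any claim that something is new, unique, unknown or untested is made for them only; others in the source may bear on it.

In a functional assay on U-937 cells (Homo sapiens) for inhibition, read by MTT assay, with a stated time of 24 h (on this read-out higher numbers stand for weaker inhibition of growth and lower numbers for stronger inhibition of growth), compound 1 `O=C1CC(c2ccc(NC(=O)c3ccc(Cl)c(C(F)(F)F)c3)cc2)=Nc2cnn(Cc3ccccc3)c2N1` gives 60 nM, while compound 2 `O=C1CC(c2ccc(NC(=O)Nc3ccc(Cl)c(C(F)(F)F)c3)cc2)=Nc2cnn(Cc3ccccc3)c2N1` gives 8680 nM, the higher of the two numbers. Going by the values given here, the only measured step, a 140-fold higher number from compound 1 to compound 2 (2.16 log units; beyond the scatter), is large, but it altered the group on the carbonyl carbon and so does not test the next change. Compound 3 `O=C1CC(c2ccc(NC(=O)Nc3cccc(Cl)c3)cc2)=Nc2cnn(Cc3ccccc3)c2N1` differs from compound 2 by 3-chlorophenyl in place of 4-chloro-3-(trifluoromethyl)phenyl on an amide-type nitrogen. Among the compounds with values here, with no measured precedent for this change, no step beyond the scatter is expected, and no direction can be favoured. The expected step is a 1.4-fold lower number from compound 2 to compound 3 (0.16 log units; within the scatter). For compound 3 the estimated value is 6000 nM, within an expected range of 1500 nM to 25000 nM.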

Compound 3, concentration for 50% growth inhibition: 670 nM
For compound 3 the middle estimate is 9.0-fold (0.95 log units) above the measured one; the measured number lies below the stated range.
By their numbers in this assay, from the lowest: compound 1; then compound 3; then compound 2.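

On the amide-type nitrogen, the aryl group proves to matter a great deal in this assay: 3-chlorophenyl in place of 4-chloro-3-(trifluoromethyl)phenyl gives a 13-fold lower number from compound 2 to compound 3 (1.11 log units; beyond the scatter). This recovers only part of the earlier loss, as an 11-fold higher number from compound 1 to compound 3 (1.05 log units; beyond the scatter) still separates the (3-chlorophenyl)amino group from the 4-chloro-3-(trifluoromethyl)phenyl group on the carbonyl carbon. No measurement here accounts for either step. The compounds shown leave open how 3-chlorophenyl behaves directly on the carbonyl carbon. They also leave open whether unsubstituted phenyl, or a ring carrying an amine, changes the number further on the amide-type nitrogen.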